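Amide nitrogen substituents on a dimethoxy indane acetic acid series

This account rests on a few compounds, and the source may have more. Where it says the series, first, only, none or still open, it means among the compounds named here.

Measured so far:
compound 1 `COc1cc2c(cc1OC)C(CC(=O)O)CC2`: 44%
compound 2 `COc1cc2c(cc1OC)C(CC(=O)Nc1ccccc1)CC2`: 42.8%
compound 3 `COc1cc2c(cc1OC)C(CC(=O)Nc1cccnc1)CC2`: 70.7%

In a functional assay on the whole organism (strain Swiss Albino) for inhibition, with Mus musculus as the target, in the writhing test, with a stated time of 1 h, at a dose of 100 mg/kg by the oral route (on this read-out lower numbers stand for less inhibition and higher numbers for more inhibition at the one dose given (going by the name of the read-out)), compound 1 gives 44% and compound 2 gives 42.8%; the step of a number 1.2 percentage points lower from compound 1 to compound 2 (within the scatter) leaves the two indistinguishable. Compound 3, with a number 26.7 percentage points higher from compound 1 to compound 3 (beyond the scatter) and a number 27.9 percentage points higher from compound 2 to compound 3 (beyond the scatter), sits clearly apart from both. Compound 2 thus stands at the lower end of the three numbers, level with compound 1 and separated from compound 3 by a step beyond the scatter.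

Compound 4 `COc1cc2c(cc1OC)C(CC(=O)Nc1ccncc1)CC2` is not yet measured. It differs from compound 2 as follows: pyridin-4-yl in place of phenyl on an amide-type nitrogen. Among the measured compounds shown here, the one step that bears on it is a number 27.9 percentage points higher from compound 2 to compound 3 (beyond the scatter), where the ring nitrogen sits at a different position of the same six-membered ring. With a single precedent, a gain of comparable size is expected in this assay, though with less certainty about its extent. The estimated step is a number 19.2 percentage points higher from compound 2 to compound 4 (beyond the scatter). For compound 4 the expected value is 62%, in the range 44% to 78%.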

Compound 4, a percentage reported as inhibition, in the whole organism at one dose (the size of the read-out at that dose, not a potency): 60.1%
Compound 4: the middle estimate sits 1.9 percentage points above what was measured; the range from low to high includes it.
By their numbers in this assay, from the lowest: compounds 2 and 1 (each within the scatter of the next); then compound 4; then compound 3.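

The gain from a ring nitrogen in the amide substituent in this assay is not tied to pyridin-3-yl: pyridin-4-yl also gives a rise beyond the scatter over the anilide (a number 17.3 percentage points higher from compound 2 to compound 4 (beyond the scatter)) and over the free acid (a number 16.1 percentage points higher from compound 1 to compound 4 (beyond the scatter)). Where the ring nitrogen sits also counts, since the two pyridine amides separate (a number 10.6 percentage points lower from compound 3 to compound 4 (beyond the scatter)), with pyridin-3-yl the higher of the pair. No measurement is available that would explain this difference between the two pyridine amides.

As far as these compounds go, how pyridin-2-yl or pyrimidin-5-yl would read on the same amide nitrogen remains open. Also open, from the compounds shown here alone, is whether a methylene link between that nitrogen and the pyridine ring would keep the gain.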